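A 2-Fluorophenyl Analogue of Compound 2

This account rests on a few compounds, and the source may have more. Where it says the series, first, only, none or still open, it means among the compounds named here.

Three compounds share a core in which a sulfamide-bearing piperidine and an aryl group sit on the same pyrimidine-type ring, and all three were tested in a functional assay on M21 cells (Homo sapiens) for antiproliferative activity, read by sulforhodamine B assay, with a stated time of 48 h; a lower number here means a stronger inhibitor of growth, a higher number a weaker inhibitor of growth. Compound 1 `CCCCc1ccc(-c2cc(N3CCC(CNS(N)(=O)=O)CC3)ncn2)cc1` gives 47200 nM. Compound 2 `NS(=O)(=O)NCC1CCN(c2cc(-c3ccc(Cl)cc3)ncn2)CC1` gives 50300 nM, the highest of the three numbers, though the step of a 1.1-fold higher number from compound 1 to compound 2 (0.03 log units; within the scatter) keeps it within the scatter of compound 1. Among the measured compounds shown here, compound 3 `COC(=O)c1ccc(-c2cc(N3CCC(CNS(N)(=O)=O)CC3)ncn2)cc1` gives 14100 nM, and the step of a 3.6-fold lower number from compound 2 to compound 3 (0.55 log units; beyond the scatter) is the only change at the aryl group that goes beyond the scatter.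

Compound 4 `NS(=O)(=O)NCC1CCN(c2cc(-c3ccccc3F)ncn2)CC1` is the next case. The change from compound 2 is 2-fluorophenyl in place of 4-chlorophenyl on an aromatic carbon. For the measured compounds named here, two measured steps bear on it, since both alter the same aryl group: the step of a 1.1-fold higher number from compound 1 to compound 2 (0.03 log units; within the scatter), which swapped one substituent for another without moving the number, and the step of a 3.6-fold lower number from compound 2 to compound 3 (0.55 log units; beyond the scatter), which did. The halogen swap here is closer to the first case than to the second, so no step beyond the scatter is expected in this assay. Compound 4 is therefore estimated at 45000 nM, in the range 20000 nM to 100000 nM, a step of a 1.1-fold lower number from compound 2 to compound 4 (0.05 log units; within the scatter) from compound 2.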

Compound 4, concentration for 50% growth inhibition: > 100000 nM
Compound 4 gave a limit, no number; the forecaster's own chance of this, stated with the estimate: 10%; at least 2.2-fold (0.34 log units) between middle value and limit.
By their numbers in this assay, from the lowest: compound 3; then compounds 1 and 2 (each within the scatter of the next). At a limit, above all of these: compound 4.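

In this assay compound 4 gives a limit and not a number: the limit of > 100000 nM in this assay, at which 1 of the 4 values shown sits. The change from 4-chlorophenyl to 2-fluorophenyl reads as an at least 1.9-fold higher number from compound 2 to compound 4 (0.29 log units; that floor lies within the scatter), so the distance between the two compounds has no upper bound, and its floor alone does not separate them. Unlike the steps among compound 1, compound 2 and compound 3, this one ends without a number, and it alters both the halogen and its place on the phenyl ring, so the earlier compounds, which offered no such double change, cannot say which part of it matters.

The compounds shown leave those two parts unseparated, since 4-fluorophenyl, 2-chlorophenyl and unsubstituted phenyl are not among them, and any one of these would show whether the halogen or its place on the ring goes with the result. They also leave open whether the lower number of compound 3 holds for a related group on the same ring, such as a carboxylic acid or an amide in place of methoxycarbonyl.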